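A few compounds are considered here, and "the series" means these few. Any claim that something is new, unique, unknown or untested is made for them only; others in the source may bear on it.

Measured compounds in an assay for displacement of a labelled ligand from 5-hydroxytryptamine receptor 4 (Homo sapiens), with a stated time of 60 min, tested at 1 uM; on this read-out lower numbers stand for less inhibition and higher numbers for more inhibition at the one concentration tested (going by the name of the read-out):
- compound 1 `COc1c(C(=O)CCC2CCN(CC3CCCCC3)CC2)cc(Cl)c2[nH]ccc12` gives 100%
- compound 2 `COc1c(C(=O)CCC2CCN(CC3CCCCC3)CC2)ccc2[nH]ccc12` gives 100%

Compound 1 stands level with compound 2 at the digits shown: the step of no change at the digits printed from compound 1 to compound 2 (within the scatter), hydrogen in place of chloro on an aromatic carbon, stays within the scatter, and both compounds sit at the top of the read-out at the single concentration tested.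

Compound 3 `COc1c(C(=O)CCC2CCN(CC3CCCCC3)CC2)cc(Cl)c2c1ccn2S(=O)(=O)c1ccccc1` is not yet measured. It differs from compound 1 by phenylsulfonyl in place of hydrogen on an aromatic nitrogen. Among the compounds with values here, no measured step touches this aromatic nitrogen; the only step recorded, from compound 1 to compound 2, concerns a different position and was flat, so it gives no guide to the size or direction of the change expected here. The read-out of compound 1 can rise no further, so any step beyond the scatter must be downward.

For compound 3 the estimate is 85%, with a range of 50% to 100%. The step from compound 1 to compound 3 is thus expected to be a number 15 percentage points lower from compound 1 to compound 3 (beyond the scatter), a modest loss that may still lie near the scatter.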

Compound 3, a percentage reported as inhibition, at one concentration (the size of the read-out at that concentration, not a potency): 62%
The estimate for compound 3 lay 23 percentage points above the measured number, within the range that was stated.
By their numbers in this assay, from the lowest: compound 3; then compounds 1 and 2 (each within the scatter of the next).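

In this assay, the aromatic nitrogen of the five-membered ring responds to substitution, whereas the chloro position gave no such signal: phenylsulfonyl in place of hydrogen gives a number 38 percentage points lower from compound 1 to compound 3 (beyond the scatter). The change does not abolish the read-out, as compound 3 still gives 62%, so this nitrogen accepts the phenylsulfonyl group at a clear cost. Compound 1 sits at the top of the read-out, so this step may understate the real loss, and no available evidence accounts for it.

On these data alone, whether the loss follows from the phenylsulfonyl group as a whole or from replacing the hydrogen at all remains open, and a methyl or benzyl group on this nitrogen would help separate the two. Readings at a single concentration also leave the potency gap between these compounds undefined.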